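The compounds below may be only part of what the source reports. "The series", "measured", "known", "first", "only" and "open" are said of these compounds alone.

In an ADME assay on the whole organism (Rattus norvegicus, strain Sprague-Dawley) for pharmacokinetics, at a dose of 0.5 mg/kg by the intravenous route (on this read-out lower numbers stand for slow clearance and higher numbers for fast clearance), the measured compounds stand as follows:

Compound 1 `Cc1cc(Cl)cc(-c2ccnc3cc(CN4C(=O)CCC4=O)sc23)c1O[C@H]1C[C@H](N)C1`: "not determined" (no result reported)
Compound 2 `O=C1CCC(=O)N1Cc1cc2nccc(-c3cc(Cl)cc4c3O[C@@H](c3onc5c3CNCC5)C4)c2s1`: 96.7 mL/min/kg
Compound 3 `Cc1cc(Cl)cc(-c2ccnc3cc(CN4C(=O)C5C(C4=O)C5(C)C)sc23)c1O[C@@H]1CCNC[C@@H]1C`: 1.83 mL/min/kg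

Compound 1 has no place on these numbers, since in this assay compound 1 gives "not determined" (no result reported) and so carries no value at all. Compound 2 gives 96.7 mL/min/kg and compound 3 gives 1.83 mL/min/kg; the two lie far apart, but they differ in several places at once, so no single change can be read from them. Compound 4 `Cc1cc(Cl)cc(-c2ccnc3cc(CN4C(=O)CCC4=O)sc23)c1OC1CCNCC1` arises from compound 1 by one change: piperidin-4-yl in place of 3-aminocyclobutyl on an oxygen on an aromatic ring. Going by the values given here, with no value for compound 1 and no step between measured compounds, neither the size nor the direction of this step in this assay can be taken from the data. Compound 4 is expected to give 20 mL/min/kg in this assay, within a range from 4 mL/min/kg to 80 mL/min/kg.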

Compound 4, clearance: 5.5 mL/min/kg
Compound 4: middle estimate off by 3.6-fold (0.56 log units), on the high side, within the range that was stated.
By their numbers in this assay, from the lowest: compound 3; then compound 4; then compound 2.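

No step can be read from compound 4, since compound 1 has no value and compound 2 and compound 3 differ from it in several places. From the compounds shown here alone, what changing 3-aminocyclobutyl to piperidin-4-yl does in this assay stays open. No supporting evidence bears on this result.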